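Methylating Two Amide Nitrogens and Cell Toxicity

The source may report more compounds than this note shows. Statements on the series, on what has been measured and on what is new or still open speak of the compounds shown alone.

The shared core carries an ester-bearing sulfur side chain on a benzene ring, joined through a carbonyl to a nitrogen that holds a small carboxamide. Compound 1 `CCCC(=O)OCSc1ccccc1C(=O)NCC(N)=O` gives > 100 uM in an ADME assay on CEM-SS cells (Homo sapiens) for cytotoxicity, read by XTT assay, with a stated time of 6 days (on this read-out higher numbers stand for lower toxicity in this test and lower numbers for higher toxicity in this test), which is a limit of the assay rather than a number. Compound 2 `CCCC(=O)OCSc1ccccc1C(=O)NC1(C(N)=O)CCCC1` likewise gives > 100 uM in this assay, again only a limit. Compound 3 `CCCC(=O)OCSc1ccccc1C(=O)N[C@@H]1CCC[C@@H]1C(N)=O` gives 90 uM in this assay. The step of an at least 1.1-fold lower number from compound 1 to compound 3 (0.04 log units; that floor lies within the scatter) is thus a floor within the scatter, and a step that the two limits leave unreadable from compound 1 to compound 2 cannot be read at all, so compound 1 stands at the ceiling of this test with two limits and one nearby number.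

Compound 4 `CCCC(=O)OCSc1ccccc1C(=O)N(C)CC(=O)NC` differs from compound 1 by methyl((methylcarbamoyl)methyl)amino in place of (carbamoylmethyl)amino on a carbonyl carbon. Among the compounds with values here, no measured step changes a nitrogen substituent in this way, so none bears directly on it. Because all values sit at or near (the limit of > 100 uM in this assay, at which 2 of the 3 values shown sit), no step beyond the scatter is expected. Compound 4 is therefore estimated at 100 uM, with a range from 45 uM to 250 uM. This expectation corresponds to a number no higher from compound 1 to compound 4 (the limit leaves the size open).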

Compound 4, half-maximal toxic concentration: 62.5 uM
Compound 4: the middle estimate sits 1.6-fold (0.20 log units) above what was measured; measured number inside the range.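

In this assay, methyl((methylcarbamoyl)methyl)amino in place of (carbamoylmethyl)amino on a carbonyl carbon gives an at least 1.6-fold lower number from compound 1 to compound 4 (0.20 log units; that floor lies within the scatter). Compound 4 gives 62.5 uM, so this change to the amide nitrogens yields a real number in this test, with 1 hydrogen-bond donor in the entering group against 2 in the one that leaves. Compound 1 has only a limit of the assay, so the step is a floor, and that floor shows no shift beyond the usual scatter: the limit of > 100 uM in this assay, at which 2 of the 4 values shown sit.

The compounds shown leave open whether methyl on one nitrogen alone would read the same as methyl on both. On these data alone, how an ethyl group on those nitrogens, or a carboxylic acid in place of the carboxamide, would read in this assay also stays open.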